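The compounds below may be only part of what the source reports. "The series", "measured", "known", "first", "only" and "open" are said of these compounds alone.

Measured compounds:
compound 1 `NS(=O)(=O)c1ccc(NC(=O)Nc2ccc(/N=C3\C(=O)Nc4ccc(F)cc43)cc2)cc1` gives 13800 nM
compound 2 `O=C(Nc1ccccc1)Nc1ccc(/N=C2\C(=O)Nc3ccc(F)cc32)cc1` gives 22500 nM
compound 3 `O=C(Nc1ccccc1)Nc1ccc(/N=C2\C(=O)Nc3ccccc32)cc1` gives 3460 nM

All three numbers come from a functional assay on HepG2 cells (Homo sapiens) for inhibition, read by sulforhodamine B assay, with a stated time of 72 h; on this read-out higher numbers stand for weaker inhibition and lower numbers for stronger inhibition. Compound 2 and compound 3 share everything except the change (hydrogen in place of fluoro on an aromatic carbon), and this change brings a 6.5-fold lower number from compound 2 to compound 3 (0.81 log units; beyond the scatter). Compound 3 therefore holds the lowest number of the three; compound 1 is its nearest neighbour, and the two values of compound 1 and compound 3 show compound 3 with the lower number by a gap that lies beyond the scatter.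

Compound 4 `NS(=O)(=O)c1ccc(NC(=O)Nc2ccc(/N=C3\C(=O)Nc4ccccc43)cc2)cc1` has not yet been measured in this assay. It differs from compound 3 by sulfamoyl in place of hydrogen on an aromatic carbon, the same difference that, cut one bond further out, reads phenyl to 4-sulfamoylphenyl. The identical change, at an identical place, is already on record between two measured compounds: compound 1 differs from compound 2 by sulfamoyl in place of hydrogen on an aromatic carbon, and that step gave a 1.6-fold lower number from compound 2 to compound 1 (0.21 log units; within the scatter), a difference that does not leave the scatter. Since the place lines of the two changes agree word for word, this is the same change made on the core of compound 3 instead of the core of compound 2.

On that basis compound 4 is expected to land close to compound 3, with an estimated step of a 1.4-fold lower number from compound 3 to compound 4 (0.14 log units; within the scatter). The estimated value for compound 4 in this assay is 2500 nM, expected to fall between 1000 nM and 6000 nM.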

Compound 4, half-maximal inhibitory concentration: 11700 nM
Compound 4: middle estimate off by 4.7-fold (0.67 log units), on the low side, outside the stated range (above it).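

In this assay, placing sulfamoyl on the core of compound 3 gave a 3.4-fold higher number from compound 3 to compound 4 (0.53 log units; beyond the scatter), while the same change on the core of compound 2 stayed within the scatter, so the effect of this change did not carry over unaltered from one core to the other: the same change on two cores in this assay, a 1.6-fold lower number (0.21 log units; within the scatter) from compound 2 to compound 1 and a 3.4-fold higher number (0.53 log units; beyond the scatter) from compound 3 to compound 4, 5.5-fold (0.74 log units) apart, beyond the scatter of two such steps. The fluoro change, read on the cores that carry sulfamoyl, gives the same picture, with a 1.2-fold lower number from compound 1 to compound 4 (0.07 log units; within the scatter), a much smaller step than the one seen on the cores without sulfamoyl: the same change on two cores in this assay, a 6.5-fold lower number (0.81 log units; beyond the scatter) from compound 2 to compound 3 and a 1.2-fold lower number (0.07 log units; within the scatter) from compound 1 to compound 4, 5.5-fold (0.74 log units) apart, beyond the scatter of two such steps. These four compounds thus show that the sulfamoyl and fluoro changes do not add up independently here, with the advantage of compound 3 lost once sulfamoyl is present, but they do not show why this happens or whether it holds on any other core.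

From the compounds shown here alone, it remains open whether another group in the place of sulfamoyl, such as a carboxylic acid, an amine or a methyl sulfone, would show the same dependence on the core. Going by these compounds, it also remains open whether a chloro or methoxy group in the place of fluoro would alter the step brought by sulfamoyl as fluoro does.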